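Swapping the aryl group on a thiazole acetic acid core

The compounds below may be only part of what the source reports. "The series", "measured", "known", "first", "only" and "open" are said of these compounds alone.

Measured compounds:
- Compound 1 `NS(=O)(=O)c1ccc(-c2nc(C(c3ccc(F)cc3)c3ccc(F)cc3)sc2CC(=O)O)cc1`: > 100000 nM
- Compound 2 `CS(=O)(=O)Nc1cccc(-c2nc(C(c3ccc(F)cc3)c3ccc(F)cc3)sc2CC(=O)O)c1`: 370 nM
- Compound 3 `COc1cc(-c2nc(C(c3ccc(F)cc3)c3ccc(F)cc3)sc2CC(=O)O)ccn1`: 380 nM

Three compounds share one core, and their potency in an in vitro functional assay on HEK285-7 cells for antagonist activity at prostaglandin D2 receptor 2 (Homo sapiens), read by BRET and beta-arrestin recruitment (a lower number here means a stronger inhibitor, a higher number a weaker inhibitor), was measured. Compound 1 reaches only the limit of this assay, giving > 100000 nM (the limit of > 100000 nM in this assay, at which 1 of the 3 values shown sits). In this assay compound 2 gives 370 nM and compound 3 gives 380 nM. Among the two numbers that are not limits, compound 3 and compound 2 sit together, the two values lying within the scatter of each other a 1.0-fold higher number from compound 2 to compound 3 (0.01 log units; within the scatter).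

Compound 4 `Nc1cc(-c2nc(C(c3ccc(F)cc3)c3ccc(F)cc3)sc2CC(=O)O)cc(F)n1` is not yet measured. It differs from compound 3 in one place: 2-amino-6-fluoropyridin-4-yl in place of 2-methoxypyridin-4-yl on an aromatic carbon. For the measured compounds named here, two measured steps bear on this position. The step from the limit was large an at least 260-fold lower number from compound 1 to compound 3 (2.42 log units; beyond the scatter), and so was an at least 270-fold lower number from compound 1 to compound 2 (2.43 log units; beyond the scatter), showing that this aryl group can swing potency strongly. The step of a 1.0-fold higher number from compound 2 to compound 3 (0.01 log units; within the scatter) shows that two rather different groups here can also give the same number. Compound 4 keeps a pyridine ring but exchanges its substituents, so the step from compound 3 is expected to be modest, a 1.6-fold higher number from compound 3 to compound 4 (0.20 log units; within the scatter). For compound 4 the estimated value in this assay is 600 nM, with a range of 150 nM to 3000 nM.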

Compound 4, half-maximal inhibitory concentration: 1400 nM
Compound 4: middle estimate off by 2.3-fold (0.37 log units), on the low side, and the stated range covers the measured number.
By their numbers in this assay, from the lowest: compounds 2 and 3 (each within the scatter of the next); then compound 4. At a limit, above all of these: compound 1.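

In this assay, the change to 2-amino-6-fluoropyridin-4-yl gives a 3.7-fold higher number from compound 3 to compound 4 (0.57 log units; beyond the scatter), and against the 3-(methanesulfonamido)phenyl group it gives a 3.8-fold higher number from compound 2 to compound 4 (0.58 log units; beyond the scatter). Keeping a pyridine ring with the same heavy-atom count therefore does not hold the number steady, and the match between compound 2 and compound 3 does not extend to every group tried here. The step from the limit remains large, an at least 71-fold lower number from compound 1 to compound 4 (1.85 log units; beyond the scatter), and it gives a minimum only: the limit of > 100000 nM in this assay, at which 1 of the 4 values shown sits.

Compound 4 differs from compound 3 in more than one substituent on the pyridine ring, so the compounds shown cannot say whether the amine, the fluorine or the loss of the methoxy group accounts for the step. A pyridine bearing only the amine, or only the fluorine, would separate these contributions.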